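Methyl-to-hydrogen loss in compound 2 guides trifluoromethyl estimate

The source may report more compounds than this note shows. Statements on the series, on what has been measured and on what is new or still open speak of the compounds shown alone.

Measured so far in a functional assay on MCF7 cells (Homo sapiens) for cytotoxicity, read by MTT assay, with a stated time of 48 h; on this read-out lower numbers stand for stronger inhibition and higher numbers for weaker inhibition:
compound 1 `COc1cc(-c2nnc3n2NC(c2ccco2)C(C(=O)c2ccc(F)cc2)S3)cc(OC)c1OC` — > 100000 nM
compound 2 `COc1cc(-c2nnc3n2NC(c2cccs2)C(C(=O)c2ccc(C)cc2)S3)cc(OC)c1OC` — 28400 nM
compound 3 `COc1cc(-c2nnc3n2NC(c2cccs2)C(C(=O)c2ccccc2)S3)cc(OC)c1OC` — > 100000 nM

Compound 1 stands at the limit of > 100000 nM in this assay, at which 2 of the 3 values shown sit; its value is therefore a limit of the assay, not a number. Compound 3 sits at the same limit. Going by the values given here, compound 2 is the only member with a numerical value.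

The unmeasured compound 4 `COc1cc(-c2nnc3n2NC(c2ccco2)C(C(=O)c2ccc(C(F)(F)F)cc2)S3)cc(OC)c1OC` differs from compound 1 by trifluoromethyl in place of fluoro on an aromatic carbon.

Among the compounds with values here, only one measured step touches the same aryl position: an at least 3.5-fold higher number from compound 2 to compound 3 (0.54 log units; beyond the scatter). That step removes a group from the aryl carbon and the number rises beyond the scatter; compound 4 goes the other way, putting a larger group on the corresponding carbon in place of fluoro. Read by analogy, the step from compound 1 to compound 4 is expected to bring the number down, by roughly the size of that measured step, though compound 1 offers only a limit as the starting point, so the outcome may again be a limit.

Estimate for compound 4: 50000 nM, range 15000 nM to 150000 nM, which is an expected step of an at least 2.0-fold lower number from compound 1 to compound 4 (0.30 log units; that floor lies within the scatter).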

Compound 4, half-maximal inhibitory concentration: 33600 nM
Compound 4: the middle estimate sits 1.5-fold (0.17 log units) above what was measured; measured number inside the range.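

In this assay, trifluoromethyl in place of fluoro on the aromatic carbon para to a large group gives an at least 2.9-fold lower number from compound 1 to compound 4 (0.47 log units; beyond the scatter), so this position now yields a step beyond the scatter in a second pair, alongside an at least 3.5-fold higher number from compound 2 to compound 3 (0.54 log units; beyond the scatter). In both pairs, the compound with the larger group at this carbon has the lower number, and compound 4 becomes the second member of the series with a numerical value. The size of the new step is only a floor because the value of compound 1 is a limit and not a number: the limit of > 100000 nM in this assay, at which 2 of the 4 values shown sit.

Going by these compounds, the true size of the step from fluoro to trifluoromethyl remains open, as does whether the same exchange would lower the number in the other ring setting of compound 2 and compound 3. On these data alone, it is also open how this carbon would respond to a nitrile, a methoxy group, an amine or a carboxylic acid, and whether a longer chain there would continue the trend seen in these two pairs.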